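Benzylamine replaces hydroxypentylamine on the shared benzimidazole-free core

The source may hold more compounds than are shown below. What is called first, only, known or untested is meant among the compounds shown, and "the series" means these compounds.

Of the compounds shown here, two have been measured in an assay on cells for inhibition of interleukin-5 receptor subunit alpha (Mus musculus), read by WST assay, with a stated time of 48 h, tested at 30 uM, in the presence of a further agent that is not named here; a higher number here means more inhibition at the concentration tested (going by the name of the read-out), a lower number less inhibition. Compound 1 `OCCCCCNCc1nc2c(OCC3CCCCC3)cccc2[nH]1` gives 23.7% and stands lowest of the two numbers. Compound 2 `OCC(CC1CCCCC1)NCc1nc2c(OCC3CCCCC3)cccc2[nH]1` gives 94.7%, a number far above compound 1 and beyond the scatter; no single-point change links these two, so their values are simply noted side by side. The unmeasured compound 3 `c1ccc(CNCc2nc3c(OCC4CCCCC4)cccc3[nH]2)cc1` differs from compound 1 by phenyl in place of 4-hydroxybutyl on a saturated chain carbon bound to an amine nitrogen. Among the measured compounds shown here, no step between measured compounds bears on this change, so its size can only be judged from the spread of the two numbers in hand. Since compound 2 reaches 94.7%, a substantial rise from compound 1 is plausible for compound 3. A step up of moderate size, beyond the scatter, is expected as a number 31.3 percentage points higher from compound 1 to compound 3 (beyond the scatter). Compound 3 is estimated at 55%, with a range from 25% to 85%.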

Compound 3, a percentage reported as inhibition, at one concentration (the size of the read-out at that concentration, not a potency): 49.3%
Estimate against measurement, compound 3: 5.7 percentage points above; the measured number falls inside the stated range.
By their numbers in this assay, from the lowest: compound 1; then compound 3; then compound 2.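

In this assay, among the compounds shown here, this is the first single-place comparison: phenyl in place of 4-hydroxybutyl on a saturated chain carbon bound to an amine nitrogen gives a number 25.6 percentage points higher from compound 1 to compound 3 (beyond the scatter) and so shows that this position responds to a change of substituent. The hydrogen-bond donor and acceptor of the 4-hydroxybutyl group leave with this change, and the number still rises, so in this pair the hydroxyl is not required for inhibition at the concentration tested. No measurement shown explains the rise.

The step combines loss of the hydroxyl with gain of the aromatic ring, so the two remain unseparated. A plain pentyl chain and a cyclohexyl group at the same place would each isolate one of these two parts of the change.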